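Swapping pyrrolidine for piperidine on a quinolinol-type Mannich base

The compounds below may be only part of what the source reports. "The series", "measured", "known", "first", "only" and "open" are said of these compounds alone.

Hmm, the core name is not allowed, so the title is corrected here:

Swapping pyrrolidin-1-yl for piperidin-1-yl in compound 3

Compound 1 `Oc1c(CN2CCCCC2)ccc2cccnc12`: 2690 nM; 2750 nM (2 entries)
Compound 2 `Oc1c(CN2CCCC2)cc(Cl)c2cccnc12`: 3210 nM; 3160 nM (2 entries)
Compound 3 `CCOCc1cc(CN2CCCC2)c(O)c2ncccc12`: 5250 nM

All three compounds were tested in a functional assay on MES-SA/Dx5 cells (Homo sapiens) for inhibition, with a stated time of 72 h, in the presence of a further agent that is not named here; a lower number here means a stronger inhibitor, a higher number a weaker inhibitor. Compound 3 has a single number to show, while two further entries for it give no single number. Its value lies within the usual scatter of those of compound 1 and compound 2, so the three cannot be ranked in this assay.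

Compound 4 `CCOCc1cc(CN2CCCCC2)c(O)c2ncccc12` has piperidin-1-yl in place of pyrrolidin-1-yl on a saturated chain carbon bound to an aromatic carbon. Among the measured compounds shown here, no measured pair isolates this change. Compound 1, with piperidin-1-yl, stands at 2690 nM; 2750 nM (2 entries), and compound 2, with pyrrolidin-1-yl, stands at 3210 nM; 3160 nM (2 entries), although they also differ elsewhere. No step beyond the scatter is therefore expected in this assay. The expected change is a 1.3-fold lower number from compound 3 to compound 4 (0.12 log units; within the scatter), which is small and within the scatter. For compound 4 the estimated value is 4000 nM, with an expected range of 1900 nM to 8500 nM.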

Compound 4, half-maximal inhibitory concentration: 7080 nM
The estimate for compound 4 lay 1.8-fold (0.25 log units) below the measured number; the measured number falls inside the stated range.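

Among the compounds shown here, the first pair to isolate piperidin-1-yl in place of pyrrolidin-1-yl on a saturated chain carbon bound to an aromatic carbon reads, in this assay, as a 1.3-fold higher number from compound 3 to compound 4 (0.13 log units; within the scatter). On this core, then, the five-membered ring and the six-membered ring can be exchanged at this place without a step beyond the scatter. Nothing shown gives a reason for the size of this step.

On these data alone, it remains open whether morpholin-4-yl or dimethylamino on the same saturated chain carbon would give a step beyond the scatter. For the compounds shown here, also open is whether the same exchange reads alike on the cores of compound 1 and compound 2, as each of these appears here with only one of the two rings.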